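Series notes: dichlorobenzyl to fluorobenzyl at the amine

The source may hold more compounds than are shown below. What is called first, only, known or untested is meant among the compounds shown, and "the series" means these compounds.

Measured in a functional assay on SF-539 cells (Homo sapiens) for inhibition, read by sulforhodamine B assay, with a stated time of 48 h; on this read-out lower numbers stand for stronger inhibition of growth and higher numbers for weaker inhibition of growth:
compound 1 `CCOC(=O)[C@H](CCC(=O)O)NC(=O)c1ccc(CNc2nc3cc(N)cc(N)c3nc2-c2ccccc2)cc1` gives < 100000 nM, which is a limit of the assay and not a number.
compound 2 `Nc1cc(N)c2nc(-c3ccccc3)c(NCc3ccc(Cl)c(Cl)c3)nc2c1` gives 4570 nM.
compound 3 `COc1cc(CNc2nc3cc(N)cc(N)c3nc2-c2ccccc2)cc(OC)c1OC` gives 1350 nM.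

Compound 2 stands highest of the two numbers obtained in this assay; the nearest is compound 3, whose number lies lower by a margin beyond the usual scatter. Compound 1 contributes only a limit (the limit of < 100000 nM in this assay, at which 1 of the 3 values shown sits).

Compound 4 `Nc1cc(N)c2nc(-c3ccccc3)c(NCc3ccc(F)cc3)nc2c1` differs from compound 2 by 4-fluorophenyl in place of 3,4-dichlorophenyl on a saturated chain carbon bound to a nitrogen on an aromatic ring. Among the measured compounds shown here, no two measured compounds differ by this change alone, so no measured step shows what it does in this assay. The expectation is a step of moderate size toward a higher number, at the edge of the scatter, with real uncertainty in both directions.

Compound 4 is therefore expected to give about 9000 nM in this assay, within a range of 2500 nM to 35000 nM. The step this estimate implies, a 2.0-fold higher number from compound 2 to compound 4 (0.29 log units; within the scatter), is an expectation only, not a measured result.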

Compound 4, concentration for 50% growth inhibition: 1820 nM
Compound 4: middle estimate off by 4.9-fold (0.69 log units), on the high side; the whole stated range lies above it.
By their numbers in this assay, from the lowest: compounds 3 and 4 (each within the scatter of the next); then compound 2.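

In this assay, among the compounds shown here, the change from 3,4-dichlorobenzyl to 4-fluorobenzyl gives the first single-place step, a 2.5-fold lower number from compound 2 to compound 4 (0.40 log units; beyond the scatter), so this position does respond to the substituents on the phenyl ring, and the 3,4-dichloro pattern is not required for the activity seen here. With this change, compound 4 at 1820 nM and compound 3 at 1350 nM lie within the scatter of each other, so two quite different substituted benzyl groups give values that cannot be told apart. Nothing measured here bears on why the step runs in this direction.

For the compounds shown here, the single step cannot separate the loss of the chlorines from the gain of the fluorine; plain benzyl and 4-chlorobenzyl would separate them. Going by these compounds, whether the phenyl ring tolerates a longer chain, such as 2-phenylethyl, also stays open.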